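This account rests on a few compounds, and the source may have more. Where it says the series, first, only, none or still open, it means among the compounds named here.

Measured so far in a functional assay on SW-620 cells (Homo sapiens) for cytotoxicity, read by colorimetric assay; on this read-out higher numbers stand for weaker inhibition and lower numbers for stronger inhibition:
- compound 1 `O=C(NO)c1ccc(CN2C(=O)/C(=C3\Nc4ccccc4\C3=N/O)c3cc(F)ccc32)cc1`: 20 nM
- compound 2 `COc1ccc2c(c1)/C(=C1/Nc3ccccc3/C1=N\O)C(=O)N2Cc1ccc(/C=C/C(=O)NO)cc1`: 40 nM
- compound 3 `O=C(/C=C/c1ccc(CN2C(=O)/C(=C3\Nc4ccccc4\C3=N/O)c3cc(F)ccc32)cc1)NO`: 50 nM

Compound 1 gives the lowest number of the three; compound 2 stays within the usual scatter of it, while compound 3 lies beyond it, a 2.5-fold higher number from compound 1 to compound 3 (0.40 log units; beyond the scatter), that step being the exchange on the pendant benzyl group. Compound 4 `O=C(NO)c1ccc(CN2C(=O)/C(=C3\Nc4ccccc4\C3=N/O)c3cc(Br)ccc32)cc1` keeps the hydroxycarbamoyl of compound 1 and changes only the halogen on the core: bromo in place of fluoro on an aromatic carbon. Going by the values given here, the single measured step at that aromatic carbon is a 1.3-fold higher number from compound 2 to compound 3 (0.10 log units; within the scatter), within the scatter. Among the compounds with values here, no measured step brings bromo to that position, so the step from compound 1 to compound 4 in this assay is expected to be a 1.1-fold higher number from compound 1 to compound 4 (0.04 log units; within the scatter), not beyond the scatter. Compound 4 is therefore estimated at 22 nM, between 8 nM and 60 nM.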

Compound 4, half-maximal inhibitory concentration: 70 nM
The estimate for compound 4 lay 3.2-fold (0.50 log units) below the measured number; measured number above the stated range.
By their numbers in this assay, from the lowest: compounds 1, 2, 3 and 4 (each within the scatter of the next, the first and the last beyond it).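

In this assay the step of a 3.5-fold higher number from compound 1 to compound 4 (0.54 log units; beyond the scatter) for bromo in place of fluoro shows that this aromatic carbon of the core is not indifferent to its substituent. The earlier step of a 1.3-fold higher number from compound 2 to compound 3 (0.10 log units; within the scatter) for fluoro in place of methoxy stayed within the scatter and gave no such sign. Nothing on hand accounts for the bromo result.

Open, as far as these compounds go, is whether chloro or a plain hydrogen at this carbon stays with fluoro or moves with bromo. Also open, from the compounds shown here alone, is whether bromo shifts the number equally with 2-(hydroxycarbamoyl)ethenyl on the benzyl group.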